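A Trifluoromethyl Step Repeated on a Second Core

A few compounds are considered here, and "the series" means these few. Any claim that something is new, unique, unknown or untested is made for them only; others in the source may bear on it.

Measured so far in a functional assay on 786-0 cells (Homo sapiens) for inhibition, read by sulforhodamine B assay, with a stated time of 48 h; on this read-out higher numbers stand for weaker inhibition of growth and lower numbers for stronger inhibition of growth:
compound 1, `O=C1C=COC(/C=C/c2ccccc2)C1`, compound 1 gives 138 uM
compound 2, `O=C1C=COC(/C=C/c2ccc(C(F)(F)F)cc2)C1`, compound 2 gives 39.6 uM
compound 3, `O=C1C=CCC(/C=C/c2ccccc2)N1`, compound 3 gives only a limit, > 1250 uM

Compound 1 and compound 2 share one core; the change between them is trifluoromethyl in place of hydrogen on an aromatic carbon, and in this assay it gave a 3.5-fold lower number from compound 1 to compound 2 (0.54 log units; beyond the scatter). Compound 3 carries a different core, and how its core differs from that of compound 1 is not broken down here. The value of compound 3 is a limit of the assay, the one at the limit of > 1250 uM in this assay, at which 1 of the 3 values shown sits, not a number.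

Compound 4, `O=C1C=CCC(/C=C/c2ccc(C(F)(F)F)cc2)N1`, is not yet measured. It relates to compound 3 as compound 2 relates to compound 1: the change is trifluoromethyl in place of hydrogen on an aromatic carbon, the same change, since both place lines read alike. On that single precedent, the step is expected to be an at least 1.3-fold lower number from compound 3 to compound 4 (0.14 log units; that floor lies within the scatter) in this assay. Because compound 3 sits at the limit of > 1250 uM in this assay, at which 1 of the 3 values shown sits, the starting point is not known, and compound 4 may itself return only a limit. The estimate for compound 4 in this assay is 900 uM, expected between 250 uM and 3000 uM.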

Compound 4, concentration for growth inhibition (reported as GI): 128 uM
Beside the measured number, compound 4's estimate is 7.0-fold (0.85 log units) above it; measured number below the stated range.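

In this assay, trifluoromethyl in place of hydrogen on an aromatic carbon again lowered the number on the second core, giving an at least 9.7-fold lower number from compound 3 to compound 4 (0.98 log units; beyond the scatter). The direction of the change carried over from one core to the other, but its size did not stay the same: the same change on two cores in this assay, a 3.5-fold lower number (0.54 log units; beyond the scatter) from compound 1 to compound 2 and an at least 9.7-fold lower number (0.98 log units; beyond the scatter) from compound 3 to compound 4, at least 2.8-fold (0.44 log units) apart, beyond the scatter of two such steps The value of compound 3, > 1250 uM, is a limit of the assay and not a number, so the step on this core is known only as a floor; its true size remains unknown, and the data do not show why the two steps differ.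

The compounds shown leave open whether another group on the same aromatic carbon, such as a nitrile, a methoxy group or a single fluorine, would also lower the number on both cores. They also leave open whether an amine or a carboxylic acid there would behave alike on the two cores, and whether any such step would hold on a third core.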